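The source may hold more compounds than are shown below. What is called first, only, known or untested is meant among the compounds shown, and "the series" means these compounds.

Among the compounds with values here, compound 1 `CCCCCCCOc1ccc(CCC(N)(CO)CO)cc1` and compound 2 `C=CCC(N)(CO)CCc1ccc(OCCCCCCC)cc1` are the two measured members. Within the data shown here, in a functional assay on the whole organism (spleen, spleen) with Rattus norvegicus as the target (on this read-out higher numbers stand for an effect only at larger amounts of compound and lower numbers for an effect already at smaller amounts), compound 1 gives 0.014 mg/kg, whereas compound 2 gives 3.1 mg/kg; compound 2 thus stands at the higher of the two numbers, and the gap to its only neighbour is a 220-fold higher number from compound 1 to compound 2 (2.35 log units; beyond the scatter). Compound 3 `CCCCCCCOc1ccc(CCC(N)(CO)CCCC)cc1` is the next member and differs from compound 2 in one place: propyl in place of vinyl on a saturated chain carbon, two bonds along the chain from an amine nitrogen. Among the measured compounds shown here, no measured step bears directly on this change; the single step so far put a vinyl in place of a hydroxy, and that hydroxy is absent from both compound 2 and compound 3, so its size offers no guide for a vinyl to propyl exchange. In this assay compound 3 is therefore expected to stay near compound 2. The expected step is a 1.0-fold lower number from compound 2 to compound 3 (0.01 log units; within the scatter), within the scatter. Compound 3 is estimated at 3 mg/kg, with a range from 0.8 mg/kg to 12 mg/kg.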

Compound 3, dose for 50% inhibition: > 10 mg/kg
Compound 3: a limit, no number; the forecaster's own chance of this, stated with the estimate: 15%; middle value at least 3.3-fold (0.52 log units) away from the limit.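

Propyl in place of vinyl gives an at least 3.2-fold higher number from compound 2 to compound 3 (0.50 log units; beyond the scatter) and so shows that this position responds to a change between two plain carbon chains, which the single hydroxy to vinyl step could not show. Propyl in place of hydroxy gives an at least 710-fold higher number from compound 1 to compound 3 (2.85 log units; beyond the scatter) and widens the gap that vinyl had already opened, so the hydroxymethyl-bearing compound 1 remains far apart from both carbon-chain compounds. In this assay compound 3 has a limit and not a number:  the limit of > 10 mg/kg in this assay, at which 1 of the 3 values shown sits.

Going by these compounds, how far compound 3 lies beyond that limit stays open, and with it the full size of both steps. Also open, on these data alone, is whether a shorter chain such as methyl or ethyl, or an aminomethyl group, at this carbon would move the value back towards that of compound 1.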